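Diethylamino in place of hydroxypyrrolidinyl on the sulfonyl

The source may hold more compounds than are shown below. What is called first, only, known or untested is meant among the compounds shown, and "the series" means these compounds.

Measured compounds:
compound 1, `O=C([C@@H]1CCCN(S(=O)(=O)c2ccc(S(=O)(=O)N3CC[C@@H](O)C3)cc2)C1)N1CCC(F)(F)CC1`, 330 nM
compound 2, `CCN(CC)S(=O)(=O)c1ccc(S(=O)(=O)N2CCC[C@@H](C(=O)N3CCC(OC)CC3)C2)cc1`, 1420 nM
compound 3, `CC(C)S(=O)(=O)c1ccc(S(=O)(=O)N2CCC[C@@H](C(=O)N3CCC(F)(F)CC3)C2)cc1`, 50 nM

In a functional assay on BXPC-3 cells (Homo sapiens) for inhibition, read by MTT assay, with a stated time of 7 days (a lower number here means a stronger inhibitor, a higher number a weaker inhibitor), compound 1 gives 330 nM, the second highest of the three numbers: compound 3 gives a lower number, compound 2 a higher one. The unmeasured compound 4 is `CCN(CC)S(=O)(=O)c1ccc(S(=O)(=O)N2CCC[C@@H](C(=O)N3CCC(F)(F)CC3)C2)cc1`. It differs from compound 1 in one place: diethylamino in place of 3-hydroxypyrrolidin-1-yl on a sulfonyl sulfur.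

Going by the values given here, one measured step bears directly on this change. It is a 6.6-fold lower number from compound 1 to compound 3 (0.82 log units; beyond the scatter), where a group without a hydrogen-bond donor on the same sulfonyl sulfur went with a lower number. Compound 4 likewise replaces the 3-hydroxypyrrolidin-1-yl with a group that carries no donor and no ring, so a step in the same direction, of modest size, is expected. Compound 2 carries the diethylamino already and gives 1420 nM, but it also differs from compound 4 in the amide part, so no step between them is shown and it tempers the expectation only loosely. The estimated step is a 1.8-fold lower number from compound 1 to compound 4 (0.26 log units; within the scatter). Compound 4 is therefore estimated at 180 nM, within a range from 60 nM to 550 nM.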

Compound 4, half-maximal inhibitory concentration: 120 nM
Compound 4: middle estimate off by 1.5-fold (0.18 log units), on the high side; measured number inside the range.
By their numbers in this assay, from the lowest: compound 3; then compound 4; then compound 1; then compound 2.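

In this assay the change gives a 2.8-fold lower number from compound 1 to compound 4 (0.44 log units; beyond the scatter), so a second group with no hydrogen-bond donor on the sulfonyl sulfur goes with a lower number, and that direction no longer rests on isopropyl alone. The two replacements do not read alike, however: a 2.4-fold higher number from compound 3 to compound 4 (0.38 log units; beyond the scatter), which leaves diethylamino short of isopropyl at this place even though it too improves on 3-hydroxypyrrolidin-1-yl. With diethylamino held constant, the amide part carries the largest step of the three, a 12-fold lower number from compound 2 to compound 4 (1.07 log units; beyond the scatter), for 4,4-difluoropiperidin-1-yl in place of 4-methoxypiperidin-1-yl on a carbonyl carbon, so the high number of compound 2 cannot be read as a verdict on diethylamino.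

The compounds shown leave open whether the lower numbers go with the loss of the hydroxyl or the loss of the ring, a question that a plain pyrrolidin-1-yl or a morpholin-4-yl on the sulfonyl sulfur would help to separate. Nothing available here gives a reason for any of these steps.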